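The source may report more compounds than this note shows. Statements on the series, on what has been measured and on what is new or still open speak of the compounds shown alone.

Measured so far:
compound 1, `CCCc1nc(CC)c(C(=O)CCN(C(=O)c2ccccc2)c2ccccc2)n1Cc1ccc(-c2ccccc2S(=O)(=O)NC(=O)OCCC(C)C)cc1F`, in an assay on isolated protein for inhibition of Type-2 angiotensin II receptor (Rattus norvegicus); a lower number here means a stronger inhibitor, a higher number a weaker inhibitor: 0.18 nM; 0.06 nM (2 entries)
compound 2, `CCCC(=O)N(CCC(=O)c1c(CC)nc(CCC)n1Cc1ccc(-c2ccccc2S(=O)(=O)NC(=O)OCCC(C)C)cc1F)c1ccccc1`, in this assay: 0.15 nM

Compound 2 stands at the only number shown for it, 0.15 nM in this assay, and it sits close to compound 1, whose repeated entries, (the several entries of compound 1 in this assay, 0.18 nM; 0.06 nM (2 entries)), show how far single readings of this kind can drift from one another. Compound 3, `CCCc1nc(CC)c(C(=O)CCN(C(=O)C(C)C)c2cccnc2)n1Cc1ccc(-c2ccccc2S(=O)(=O)NC(=O)OCCC(C)C)cc1F`, has not been measured in this assay. It differs from compound 2 in one place: (isopropylcarbonyl)(pyridin-3-yl)amino in place of phenyl(propylcarbonyl)amino on a saturated chain carbon, two bonds along the chain from a carbonyl carbon.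

Within the data shown here, no measured pair in this set shares exactly this change, so the expected size of the step is uncertain. Because compound 2 gives 0.15 nM in this assay and compound 1 gives 0.18 nM; 0.06 nM (2 entries) in the same narrow region, a step for compound 3 that stays within the usual scatter, or a mild weakening, is expected. The step from compound 2 to compound 3 is estimated as a 2.0-fold higher number from compound 2 to compound 3 (0.30 log units; within the scatter), and compound 3 is expected to give about 0.3 nM, within 0.08 nM to 1.2 nM.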

Compound 3, half-maximal inhibitory concentration: 1 nM
Estimate against measurement, compound 3: 3.3-fold (0.52 log units) below; low and high end bracket the measured number.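

In this assay, among these compounds, the first readable step at this position shows that the group on the saturated chain carbon, two bonds along the chain from a carbonyl carbon, can shift the number: putting (isopropylcarbonyl)(pyridin-3-yl)amino in place of phenyl(propylcarbonyl)amino gives a 6.7-fold higher number from compound 2 to compound 3 (0.82 log units; beyond the scatter). Even after this change, compound 3 reads 1 nM. This is a single pair, and repeated readings of one compound can also spread, so the step carries only modest weight: the several entries of compound 1 in this assay, 0.18 nM; 0.06 nM (2 entries)

The entering group differs in two ways at once, pyridin-3-yl for phenyl and isopropylcarbonyl for propylcarbonyl, and the compounds shown do not separate these two changes. On these data alone, it also stays open how a pyridin-4-yl group or a longer chain such as pentylcarbonyl would read at this position.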